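Thiophene isomer swap across two related cores

The source may report more compounds than this note shows. Statements on the series, on what has been measured and on what is new or still open speak of the compounds shown alone.

Measured compounds:
compound 1 `NC(=O)c1ncn2c(=O)n(Cc3cccs3)nnc12` — > 50000 nM
compound 2 `NC(=O)c1ncn2c(=O)n(Cc3ccsc3)nnc12` — > 50000 nM
compound 3 `NC(=O)c1nc[nH]c1N/N=N/Cc1cccs1` — > 50000 nM

In a functional assay on SNB-19 cells (Homo sapiens) for inhibition, read by MTT assay, with a stated time of 7 days (a higher number here means a weaker inhibitor of growth, a lower number a stronger inhibitor of growth), compound 1 reports only a limit, > 50000 nM. Compound 2 likewise reports only a limit in this assay, > 50000 nM. The step that the two limits leave unreadable from compound 1 to compound 2 is therefore unreadable; the change is thiophen-3-yl in place of thiophen-2-yl on a saturated chain carbon bound to an aromatic nitrogen. Compound 3, on a different core, also returns only a limit, > 50000 nM. The difference between the two cores is not broken down here.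

Compound 4 `NC(=O)c1nc[nH]c1N/N=N/Cc1ccsc1` is not yet measured. It carries the same kind of change, (thiophen-3-yl in place of thiophen-2-yl on a saturated chain carbon bound to a double-bonded nitrogen), the place being a saturated chain carbon bound to a double-bonded nitrogen rather than to an aromatic nitrogen. Among the measured compounds shown here, every value so far sits at the limit of > 50000 nM in this assay, at which 3 of the 3 values shown sit, so the step from compound 3 to compound 4 is expected to be flat, a step that the limit leaves unreadable from compound 3 to compound 4. Compound 4 is expected at 100000 nM, most likely again as a limit.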

Compound 4, concentration for 50% growth inhibition: > 50000 nM
Compound 4: a limit, no number (the forecaster's own chance of this, stated with the estimate: 90%); the middle value lies beyond the limit too.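

Compound 3 and compound 4 each give only a limit in this assay, so the step between them cannot be read: the limit of > 50000 nM in this assay, at which 4 of the 4 values shown sit.

The compounds shown leave open how thiophen-2-yl and thiophen-3-yl compare on either core.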